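Three Measured Compounds, a Fourth Expected, in a Cell Assay

This account rests on a few compounds, and the source may have more. Where it says the series, first, only, none or still open, it means among the compounds named here.

Compound 1, `Clc1ccc2[nH]c(-c3cn(-c4ccccc4)nc3-c3ccccc3)nc2c1`, in an ADME assay on HaCaT cells (Homo sapiens) for cytotoxicity, read by MTT assay, with a stated time of 48 h (a lower number here means a stronger inhibitor, a higher number a weaker inhibitor), gives > 50000 nM, which is a limit of the assay rather than a number.
Compound 2, `Brc1ccc2[nH]c(-c3cn(-c4ccccc4)nc3-c3ccccc3)nc2c1`, in this assay gives > 50000 nM, again only a limit.
Compound 3, `Clc1ccc(-c2nn(-c3ccccc3)cc2-c2nc3cc(Cl)ccc3[nH]2)cc1`, in this assay gives > 50000 nM, also only a limit.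

Compound 2 differs from compound 1 by bromo in place of chloro on an aromatic carbon, and the step is a step that the two limits leave unreadable from compound 1 to compound 2. Compound 3 differs from compound 1 in its core by chloro in place of hydrogen on an aromatic carbon, and that step is a step that the two limits leave unreadable from compound 1 to compound 3. None of the three measured values is a real number: each sits at the limit of > 50000 nM in this assay, at which 3 of the 3 values shown sit, so no change can be read from any pair.

Compound 4, `Clc1ccc(-c2nn(-c3ccccc3)cc2-c2nc3cc(Br)ccc3[nH]2)cc1`, has not yet been measured. It differs from compound 3 by bromo in place of chloro on an aromatic carbon, the same change as that from compound 1 to compound 2, at a place described in identical words. Because the limit of > 50000 nM in this assay, at which 3 of the 3 values shown sit, holds every measured value, the step is expected to be a step that the limit leaves unreadable from compound 3 to compound 4. Compound 4 is therefore expected to give about 60000 nM in this assay, most likely reported once more only as a limit.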

Compound 4, half-maximal inhibitory concentration: > 50000 nM
Compound 4 ended at the assay's limit; the forecaster's own chance of this, stated with the estimate: 85%; the middle value lies beyond the limit too.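

In this assay compound 4 also gives only a limit, not a number, so its steps from compound 2 and compound 3 cannot be read: the limit of > 50000 nM in this assay, at which 4 of the 4 values shown sit. In this assay the compounds shown leave open how far any of the four lies beyond that limit, and whether bromo in place of chloro, or chloro in place of hydrogen, changes the result at all.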